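Swapping Methoxy for Trifluoromethyl on a Sulfonyl Phenyl

The source may report more compounds than this note shows. Statements on the series, on what has been measured and on what is new or still open speak of the compounds shown alone.

Two compounds share one core and differ at one amine nitrogen in a ring. Compound 1 `O=C(/C=C/c1ccccc1)c1ccc(N2CCN(c3ccccc3Cl)CC2)cc1` carries a 2-chlorophenyl there; in a functional assay on the whole organism (strain Kunming) for inhibition, with Mus musculus as the target, with a stated time of 1 h, at a dose of 40 mg/kg by the oral route (a lower number here means less inhibition, a higher number more inhibition at the dose given (going by the name of the read-out)), compound 1 gives 4.71%. Compound 2 `COc1ccc(S(=O)(=O)N2CCN(c3ccc(C(=O)/C=C/c4ccccc4)cc3)CC2)cc1` carries a (4-methoxyphenyl)sulfonyl instead, and in this assay compound 2 gives 45.2%. Among the compounds with values here, that exchange is the only measured step, a number 40.5 percentage points higher from compound 1 to compound 2 (beyond the scatter), and on these two numbers compound 2 stands highest, with compound 1 well beneath it beyond the scatter.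

Within the data shown here, compound 3 `O=C(/C=C/c1ccccc1)c1ccc(N2CCN(S(=O)(=O)c3ccc(C(F)(F)F)cc3)CC2)cc1` keeps the sulfonyl arrangement of compound 2 and alters only one group on an aromatic carbon of a six-membered aromatic ring of carbon only: trifluoromethyl in place of methoxy on an aromatic carbon. Among the measured compounds shown here, no measured step touches this kind of change; the one step that exists, a number 40.5 percentage points higher from compound 1 to compound 2 (beyond the scatter), concerns a different part of the molecule and says nothing about trading one small group for another on that ring. With nothing to lean on, the expectation is a step of no size beyond the scatter, a number 0.2 percentage points lower from compound 2 to compound 3 (within the scatter). Compound 3 is therefore estimated at 45%, with a range from 25% to 65%.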

Compound 3, a percentage reported as inhibition, in the whole organism at one dose (the size of the read-out at that dose, not a potency): 47.9%
Beside the measured number, compound 3's estimate is 2.9 percentage points below it; measured number inside the range.
By their numbers in this assay, from the lowest: compound 1; then compounds 2 and 3 (each within the scatter of the next).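

In this assay, the exchange of methoxy for trifluoromethyl on the sulfonyl phenyl ring gives a number 2.7 percentage points higher from compound 2 to compound 3 (within the scatter), so this step shows no real change in the read-out. The two groups are quite different on paper: methoxy has 2 heavy atoms and 1 hydrogen-bond acceptor, while trifluoromethyl has 4 heavy atoms and 0 hydrogen-bond acceptors, yet the level seen for compound 2 also holds for compound 3 and does not depend on methoxy in particular. Nothing in the available data offers an explanation for why these two groups read alike.

Still open, from the compounds shown here alone, is whether this position accepts any group or only these two: a primary amine, a carboxylic acid or a longer chain such as butoxy on the same ring could give a very different read-out from methoxy and trifluoromethyl. Also open, going by these compounds, is whether the same exchange would read alike at another place on that ring, or at a different oral dose, since a single dose gives the size of an effect and not a potency.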